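The source may hold more compounds than are shown below. What is called first, only, known or untested is meant among the compounds shown, and "the series" means these compounds.

Working notes on the series in a functional assay on HCT-116 cells (Homo sapiens), read by MTT assay, with a stated time of 72 h; a lower number here means a stronger inhibitor, a higher number a weaker inhibitor. Compound 3 `Cc1nc(N)c2c(-c3cc4ccccc4o3)cn([C@@H]3O[C@H](CO)[C@@H](O)[C@H]3O)c2n1` carries a 1-benzofuran-2-yl group; in this assay compound 3 gives > 20000 nM, which is a limit of the assay and not a number. Compound 1 `Cc1nc(N)c2c(-c3ccccc3)cn([C@@H]3O[C@H](CO)[C@@H](O)[C@H]3O)c2n1` differs from it by phenyl in place of 1-benzofuran-2-yl on an aromatic carbon. In this assay compound 1 gives > 100000 nM, again a limit. The step that the two limits leave unreadable from compound 3 to compound 1 therefore cannot be read, since both ends sit at limits, as the limit of > 100000 nM in this assay, at which 1 of the 3 values shown sits, and the limit of > 20000 nM in this assay, at which 2 of the 3 values shown sit, show. Compound 2 `O=c1[nH]cnc2c1c(-c1cc3ccccc3o1)cn2[C@@H]1O[C@H](CO)[C@@H](O)[C@H]1O` keeps the 1-benzofuran-2-yl group of compound 3 on a different core; the difference between the two cores is not broken down here. In this assay compound 2 gives > 20000 nM, a limit. Compound 4 `O=c1[nH]cnc2c1c(-c1ccccc1)cn2[C@@H]1O[C@H](CO)[C@@H](O)[C@H]1O`, not yet measured, is reached from compound 2 by the same change, (phenyl in place of 1-benzofuran-2-yl on an aromatic carbon), at the same place. Because a step that the two limits leave unreadable from compound 3 to compound 1 stayed unreadable between limits, the step that the limit leaves unreadable from compound 2 to compound 4 is expected to be small. Compound 4 is thus estimated at 50000 nM, between 15000 nM and 200000 nM, and most likely reported only as a limit.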

Compound 4, half-maximal inhibitory concentration: > 100000 nM
Compound 4: no number, only a limit (the forecaster's own chance of this, stated with the estimate: 85%); middle value at least 2.0-fold (0.30 log units) from the limit.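

Compound 2 and compound 4 both stand at limits in this assay, not at numbers, and the step between them cannot be read. The compounds shown leave open how strongly any of them inhibits, and whether phenyl or 1-benzofuran-2-yl gives the stronger inhibitor on either core.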